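Amide for Aryl on the Bridged Amine: Clearance Outlook

The source may hold more compounds than are shown below. What is called first, only, known or untested is meant among the compounds shown, and "the series" means these compounds.

Compound 1 `Cn1cc(-c2ncc(C#N)c(N3C[C@@H]4C[C@H]3CN4CC3CC3)n2)cn1` in an ADME assay on microsomes from liver (Homo sapiens) for pharmacokinetics (on this read-out higher numbers stand for fast clearance and lower numbers for slow clearance), gives < 16 mL/min/kg, a limit of the assay.
Compound 2 `C[C@@H]1C[C@H]1C(=O)N1CCN(c2cnc(C#N)c(-c3cnn(C)c3)n2)C[C@H]1C` in this assay gives < 16 mL/min/kg, again a limit.
Compound 3 `Cn1cc(-c2ncc(C#N)c(N3C[C@@H]4C[C@H]3CN4c3cccc(F)c3)n2)cn1` in this assay gives 76 mL/min/kg.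

Going by the values given here, compound 3 thus supplies the only number in the set; the other two values sit at the limit of < 16 mL/min/kg in this assay, at which 2 of the 3 values shown sit. Compound 4 `Cn1cc(-c2ncc(C#N)c(N3C[C@@H]4C[C@H]3CN4C(=O)C3CC3)n2)cn1` has not yet been measured. It differs from compound 3 in one place: cyclopropylcarbonyl in place of 3-fluorophenyl on an amine nitrogen in a ring.

Among the compounds with values here, one measured step bears on this change. The move an at least 4.7-fold higher number from compound 1 to compound 3 (0.67 log units; beyond the scatter) shows that placing 3-fluorophenyl on that ring nitrogen in place of cyclopropylmethyl raised clearance markedly. Compound 4 removes the 3-fluorophenyl and brings in cyclopropylcarbonyl, so the change runs counter to that step, and a drop in this assay is expected for compound 4, plausibly of a size comparable to the rise seen from compound 1 to compound 3, with the exact extent uncertain because compound 1 sits at the limit of < 16 mL/min/kg in this assay, at which 2 of the 3 values shown sit. The step of a 4.8-fold lower number from compound 3 to compound 4 (0.68 log units; beyond the scatter) is the estimated outcome. Compound 4 is therefore expected to give about 16 mL/min/kg, within a range of 6 mL/min/kg to 38 mL/min/kg, with a real chance that only a limit is reported.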

Compound 4, clearance: < 16 mL/min/kg
Compound 4 ended at the assay's limit; the forecaster's own chance of this, stated with the estimate: 45%; the middle value lies on the limit itself.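

In this assay, the step of an at least 4.7-fold lower number from compound 3 to compound 4 (0.67 log units; beyond the scatter) shows that the clearance number of compound 3 does not persist when cyclopropylcarbonyl replaces 3-fluorophenyl on this amine nitrogen in a ring. The earlier compounds shown here showed a low reading at this position only with cyclopropylmethyl, and compound 4 now extends it to a group joined through a carbonyl. The step from compound 1 to compound 4 cannot be read, as both values are limits, so cyclopropylcarbonyl and cyclopropylmethyl cannot be ranked, and 3-fluorophenyl remains the only group at this position with a number above the limit, while the other compounds gather at that limit: the limit of < 16 mL/min/kg in this assay, at which 3 of the 4 values shown sit.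

The compounds shown leave open how far under the limit compound 1 and compound 4 actually lie, and whether the higher number of compound 3 goes with the aromatic ring or with its fluorine. An unsubstituted phenyl, a pyridine ring or a small acetyl group on the same nitrogen would bear on that question.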